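The source may hold more compounds than are shown below. What is called first, only, known or untested is meant among the compounds shown, and "the series" means these compounds.

Measured in a functional assay on HL-60 cells (Homo sapiens) for inhibition, read by CCK-8 assay, with a stated time of 48 h; a lower number here means a stronger inhibitor, a higher number a weaker inhibitor:
- Compound 1 `Cc1cc(C)cc(NC(=O)NCCNS(=O)(=O)c2ccc(-c3ccccc3Oc3ccc([N+](=O)[O-])c([N+](=O)[O-])c3)s2)c1` gives 9100 nM
- Compound 2 `Nc1ccc(Oc2ccccc2-c2ccc(S(=O)(=O)NCCNC(=O)Nc3ccc(Cl)cc3)s2)cc1` gives > 50000 nM, a limit
- Compound 3 `Cc1cc(C)cc(NC(=O)NCCNS(=O)(=O)c2ccc(-c3ccccc3OCc3ccccc3)s2)c1` gives 2200 nM

Of the two actual numbers, the lower belongs to compound 3 at 2200 nM. The other number belongs to compound 1 at 9100 nM. Compound 2 reaches only the limit of > 50000 nM, and it also carries the 4-aminophenoxy group, though it differs elsewhere as well.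

Compound 4 `Cc1cc(C)cc(NC(=O)NCCNS(=O)(=O)c2ccc(-c3ccccc3Oc3ccc(N)cc3)s2)c1` has 4-aminophenyl in place of benzyl on an oxygen on an aromatic ring. The closest measured change is a 4.1-fold lower number from compound 1 to compound 3 (0.62 log units; beyond the scatter), where benzyl replaced 3,4-dinitrophenyl at that same place. That step was modest and beyond the scatter. Going back from benzyl to a substituted phenyl is therefore expected to raise the number by a similar modest amount in this assay, and the limit for compound 2 points the same way. The estimated step is a 3.6-fold higher number from compound 3 to compound 4 (0.56 log units; beyond the scatter). For compound 4 the expected value is 8000 nM, with an estimated range of 2500 nM to 30000 nM.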

Compound 4, half-maximal inhibitory concentration: > 50000 nM
Compound 4: only a limit was reported; the forecaster's own chance of this, stated with the estimate: 15%; middle value at least 6.2-fold (0.79 log units) from the limit.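

Among these compounds, the value for compound 4 is a limit, not a number, yet it shows that this place on the oxygen tolerates far less change than the earlier compounds suggested. In this assay putting 4-aminophenyl in place of benzyl gives an at least 22-fold higher number from compound 3 to compound 4 (1.35 log units; beyond the scatter) and this large step contrasts with the merely modest earlier change at the same place. The two phenyl ethers are not interchangeable either, since 4-aminophenyl in place of 3,4-dinitrophenyl gives an at least 5.4-fold higher number from compound 1 to compound 4 (0.73 log units; beyond the scatter) and so the substituent on that ring matters as well.

From the compounds shown here alone, what a methoxy group or an acetamide in place of the amine would do on this ring stays open. The step between compound 2 and compound 4 cannot be read, since both stand only as limits: the limit of > 50000 nM in this assay, at which 2 of the 4 values shown sit.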